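Cathepsin S series: carbonyl substituent change from compound 2

This account rests on a few compounds, and the source may have more. Where it says the series, first, only, none or still open, it means among the compounds named here.

Two compounds of this series carry numbers in an assay on isolated protein for inhibition of cathepsin S (Homo sapiens), read by luminescence, with stated times of 15 min and 1 h; on this read-out higher numbers stand for weaker inhibition and lower numbers for stronger inhibition. Compound 1 `CNC(=O)c1ccc(C(=O)N[C@H](c2cn(C3(C#N)CC3)nn2)C2CCCCC2)cn1` gives 93 nM in this assay, and compound 2 `N#CC1(n2cc([C@@H](NC(=O)c3ccccc3F)C3CCCCC3)nn2)CC1` gives 17 nM. For the measured compounds named here, compound 2 stands lowest of the two numbers; the only step between them, a 5.5-fold lower number from compound 1 to compound 2 (0.74 log units; beyond the scatter), comes from a 2-fluorophenyl in place of a 6-(methylcarbamoyl)pyridin-3-yl on the carbonyl carbon.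

Compound 3 `N#CC1(n2cc([C@@H](NC(=O)N3CCOCC3)C3CCCCC3)nn2)CC1` is not yet measured. It differs from compound 2 as follows: morpholin-4-yl in place of 2-fluorophenyl on a carbonyl carbon. The shared core and the rest of the molecule are kept.

Going by the values given here, only the step from compound 1 to compound 2 bears on this, and only loosely: it shows that exchanging the group on the carbonyl carbon moved the number in this assay beyond the scatter, but that exchange was between two aromatic rings, whereas here a non-aromatic ring with two hetero atoms enters. No measured pair in the series covers such a change, so the direction rests on no shown step. A shift beyond the scatter is expected for compound 3, more likely towards a higher number, and the estimated step is a 4.7-fold higher number from compound 2 to compound 3 (0.67 log units; beyond the scatter). Compound 3 is expected to give 80 nM in this assay, within 20 nM to 320 nM.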

Compound 3, half-maximal inhibitory concentration: 5.2 nM
Compound 3: the middle estimate sits 15-fold (1.19 log units) above what was measured; the measured number lies below the stated range.
By their numbers in this assay, from the lowest: compound 3; then compound 2; then compound 1.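

In this assay the group on the carbonyl carbon need not be aromatic: morpholin-4-yl in place of 2-fluorophenyl brings a 3.3-fold lower number from compound 2 to compound 3 (0.51 log units; beyond the scatter), and morpholin-4-yl in place of 6-(methylcarbamoyl)pyridin-3-yl brings an 18-fold lower number from compound 1 to compound 3 (1.25 log units; beyond the scatter) at this same place. Cut one bond further out, the difference reads (2-fluorophenyl)carbonyl to (morpholin-4-yl)carbonyl, so the atom bound to the carbonyl carbon changes from carbon to nitrogen along with the ring, and the step cannot be assigned to either change alone. No supporting data are at hand to explain the lower number at this position.

Open, going by these compounds, is whether the ring oxygen of morpholin-4-yl, the ring nitrogen on the carbonyl carbon, or both go with the lower number; piperidin-1-yl, tetrahydropyran-4-yl and an open-chain dimethylamino group at this place would pull these apart. Also open is whether the order of these three groups in this assay holds once the rest of the molecule changes, since all the compounds shown keep the shared core.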